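The source may hold more compounds than are shown below. What is called first, only, known or untested is meant among the compounds shown, and "the series" means these compounds.

Measured compounds:
- compound 3 `Cc1ccc(C(=O)/C=C/c2ccc3c(c2)B(O)OC3)cc1` gives 8300 nM in a toxicity assay on MCF-10A cells (Homo sapiens) for cytotoxicity, read by MTT assay, with a stated time of 48 h; a lower number here means a stronger inhibitor, a higher number a weaker inhibitor
- compound 1 `O=C(/C=C/c1ccc2c(c1)B(O)OC2)c1cccs1` gives 13800 nM
- compound 2 `O=C(/C=C/c1ccc2c(c1)B(O)OC2)c1ccc(I)cc1` reaches only the limit of this assay, > 100000 nM (the limit of > 100000 nM in this assay, at which 1 of the 3 values shown sits)

Compound 3 sits at the lowest of the two numbers; the nearest is compound 1, and the step from compound 1 to compound 3 is a 1.7-fold lower number from compound 1 to compound 3 (0.22 log units; within the scatter). Compound 4 `Cc1cccc(C(=O)/C=C/c2ccc3c(c2)B(O)OC3)c1` differs by 3-methylphenyl in place of 4-methylphenyl on a carbonyl carbon. Going by the values given here, no measured step moves a substituent within one ring: an at least 12-fold lower number from compound 2 to compound 3 (1.08 log units; beyond the scatter) swaps the group itself, and an at least 7.2-fold higher number from compound 1 to compound 2 (0.86 log units; beyond the scatter) swaps the whole aryl. With the aryl kept and only the methyl moved, no step beyond the scatter is expected; the estimated step is a 1.1-fold higher number from compound 3 to compound 4 (0.04 log units; within the scatter). Compound 4 is estimated at 9000 nM, between 3000 nM and 27000 nM.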

Compound 4, half-maximal inhibitory concentration: 15900 nM
Estimate against measurement, compound 4: 1.8-fold (0.25 log units) below; low and high end bracket the measured number.
By their numbers in this assay, from the lowest: compounds 3, 1 and 4 (each within the scatter of the next). At a limit, above all of these: compound 2.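

In this assay, the methyl moved within the aryl gives the first step of this kind in the series (a 1.9-fold higher number from compound 3 to compound 4 (0.28 log units; within the scatter)), so 4-methylphenyl and 3-methylphenyl on a carbonyl carbon are not told apart here. With the methyl moved, compound 4 also stays within the scatter of the thiophen-2-yl compound (a 1.2-fold higher number from compound 1 to compound 4 (0.06 log units; within the scatter)) and keeps a clear distance from the 4-iodophenyl compound (an at least 6.2-fold lower number from compound 2 to compound 4 (0.79 log units; beyond the scatter)). The value of compound 2 is a limit, not a number: the limit of > 100000 nM in this assay, at which 1 of the 4 values shown sits.

Open, from the compounds shown here alone, is whether an amine or a carboxylic acid in place of the methyl stays with compound 3 and compound 4. Also open, going by these compounds, is whether chloro or bromo in place of iodo stays with compound 2.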